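Methoxy Substitution on a Shared Core and Cytotoxicity

The source may hold more compounds than are shown below. What is called first, only, known or untested is meant among the compounds shown, and "the series" means these compounds.

Compound 1 `COc1ccc([C@H]2CC(C)(O)[C@@H]3CC[C@@H](C)C[C@H]3O2)c(OC)c1`: > 937000 nM
Compound 2 `COc1cc(OC)c([C@H]2CC(C)(O)[C@@H]3CC[C@@H](C)C[C@H]3O2)cc1OC`: > 857000 nM
Compound 3 `C[C@@H]1CC[C@@H]2[C@@H](C1)O[C@@H](c1ccccc1)CC2(C)F`: 65000 nM

In an ADME assay on MDCK cells (Canis lupus familiaris) for cytotoxicity, read by MTT assay, with a stated time of 48 h (on this read-out lower numbers stand for higher toxicity in this test and higher numbers for lower toxicity in this test), compound 1 gives > 937000 nM, which is a limit of the assay and not a number. Compound 2 gives > 857000 nM, again a limit of the assay. Going by the values given here, compound 3 gives 65000 nM, the only number among the three. The step from compound 1 to compound 2, a step that the two limits leave unreadable from compound 1 to compound 2, comes from the change (methoxy in place of hydrogen on an aromatic carbon). How the core of compound 3 differs from that of compound 1 is not broken down here.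

Compound 4 `COc1ccc([C@H]2CC(C)(F)[C@@H]3CC[C@@H](C)C[C@H]3O2)cc1` is not yet measured. It differs from compound 3 by methoxy in place of hydrogen on an aromatic carbon, the same kind of change as from compound 1 to compound 2, though the place differs: in compound 2 the new methoxy sits ortho to a methoxy group, meta to a large group and para to a methoxy group, whereas in compound 4 it sits para to a large group. Because compound 1 sits at the limit of > 937000 nM in this assay, at which 1 of the 3 values shown sits, and compound 2 at the limit of > 857000 nM in this assay, at which 1 of the 3 values shown sits, both limits, the expectation is that adding a methoxy moves toward lower toxicity, and the estimated step is a 2.3-fold higher number from compound 3 to compound 4 (0.36 log units; beyond the scatter). For compound 4 the estimate in this assay is 150000 nM, expected between 50000 nM and 500000 nM.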

Compound 4, half-maximal cytotoxic concentration: 171000 nM
Beside the measured number, compound 4's estimate is 1.1-fold (0.06 log units) below it; the measured number falls inside the stated range.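

In this assay, methoxy in place of hydrogen on an aromatic carbon, para to a large group, gives a 2.6-fold higher number from compound 3 to compound 4 (0.42 log units; beyond the scatter), which shows the direction and size of this change on one core only. This does not show that the change carries over to another core, because the one other pair with this kind of change cannot be read, and compound 1 stands at a limit of the assay and not a number: the limit of > 937000 nM in this assay, at which 1 of the 4 values shown sits.
Compound 2 likewise stands at a limit of the assay and not a number: the limit of > 857000 nM in this assay, at which 1 of the 4 values shown sits.

The compounds shown leave open whether methoxy elsewhere on the aromatic ring of compound 3 would give a similar step. They also leave open what an amine or a carboxylic acid on that same aromatic carbon would do in this assay.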